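Hydroxamic acid series: HDAC6 single-concentration inhibition notes

The source may hold more compounds than are shown below. What is called first, only, known or untested is meant among the compounds shown, and "the series" means these compounds.

Measured compounds:
compound 1 `Cc1ccccc1CN1CCC(c2noc(COc3ccc(/C=C/C(=O)NO)cc3)n2)CC1` — compound 1 gives 68%
compound 2 `C=CCN1CCC(c2noc(COc3ccc(CCC(=O)NO)cc3)n2)CC1` — compound 2 gives 15%
compound 3 `CN(Cc1nc(C2CCN(Cc3ccccc3)CC2)no1)c1ncc(C(=O)NO)cn1` — compound 3 gives 63%

All three were read in an assay on isolated protein for inhibition of protein deacetylase HDAC6 (Homo sapiens), read by fluorescence, with a stated time of 1 h, tested at 100 nM; a lower number here means less inhibition, a higher number more inhibition at the concentration tested (going by the name of the read-out). Compound 3 stands second highest of the three numbers. Its nearest neighbour is compound 1, whose number is higher by an amount within the usual scatter, so no order can be drawn between compound 1 and compound 3. The furthest is compound 2, whose number lies well below compound 3, beyond the scatter. Among the measured compounds shown here, no pair of measured compounds differs in a single place, so no single-point step can be drawn from the measured set.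

The next compound, compound 4 `CN(Cc1nc(C2CCN(Cc3ccc(F)cc3F)CC2)no1)c1ncc(C(=O)NO)cn1`, differs from compound 3 in one place: 2,4-difluorophenyl in place of phenyl on a saturated chain carbon bound to an amine nitrogen in a ring. The hydroxamic acid and the rest of the core are unchanged.

Nothing in the measured data isolates the effect of this kind of change. With the core and hydroxamic acid kept, the expectation in this assay is a step of no more than the scatter, in either direction. Compound 4 is therefore expected near the value of compound 3, with the expected step of a number 1 percentage points lower from compound 3 to compound 4 (within the scatter) small. The estimate for compound 4 is 62%, in the range 45% to 78%.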

Compound 4, a percentage reported as inhibition, at one concentration (the size of the read-out at that concentration, not a potency): 66%
For compound 4 the middle estimate is 4 percentage points below the measured one; measured number inside the range.
By their numbers in this assay, from the lowest: compound 2; then compounds 3, 4 and 1 (each within the scatter of the next).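

In this assay, the series now has its first step at a single place: 2,4-difluorophenyl in place of phenyl on a saturated chain carbon bound to an amine nitrogen in a ring gives a change (a number 3 percentage points higher from compound 3 to compound 4 (within the scatter)). Among the compounds shown here, with the shared core and the hydroxamic acid kept, this position carries the benzyl to 2,4-difluorobenzyl change with no step that can be told from the scatter, so no order can be drawn between compound 3 and compound 4, and the two added fluorine atoms leave the reading at this one concentration unresolved from that of the parent. No measurement at hand bears on why the step is this size.

From the compounds shown here alone, whether a benzyl carrying a nitrile or a carboxylic acid, or a phenethyl in place of benzyl, would give a step beyond the scatter on this core remains open. Also open, going by these compounds, is whether benzyl to 2,4-difluorobenzyl would read the same on the core of compound 1, where the benzyl group already carries a methyl.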